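Hydroxy on the Ester Chain: Compound 1 to Compound 3

The compounds below may be only part of what the source reports. "The series", "measured", "known", "first", "only" and "open" are said of these compounds alone.

Compound 1 `CCOC(=O)/C=C/c1ccc2c(c1)C(=O)C(=O)N2Cc1ccc(OC)cc1` is the reference point of this small set. In a functional assay on HepG2 cells (Homo sapiens) for cytotoxicity, read by MTT assay, with a stated time of 48 h (on this read-out lower numbers stand for stronger inhibition and higher numbers for weaker inhibition), compound 1 gives 90 nM, the lowest of the two numbers at hand. The only measured comparator, compound 2 `COC(=O)/C=C/c1ccc2c(c1)/C(=N/O)C(=O)N2Cc1ccc(Br)cc1`, differs from it in several places at once; in this assay compound 2 gives 9960 nM, a much higher number, and the gap lies beyond the scatter. Among the compounds with values here, no single-change step links these two, so nothing about the effect of any one change can be read from them.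

Compound 3 `COc1ccc(CN2C(=O)C(=O)c3cc(/C=C/C(=O)OCCO)ccc32)cc1` is the untested analogue of compound 1: hydroxy in place of hydrogen on a saturated chain carbon, two bonds along the chain from an oxygen next to a carbonyl group. Within the data shown here, no measured pair shows a step of this kind, so the expectation rests on compound 1 alone. The step from compound 1 to compound 3 is expected as a 1.7-fold higher number from compound 1 to compound 3 (0.22 log units; within the scatter), a small move toward a higher number, within or just past the scatter. Compound 3 is therefore estimated at 150 nM, in the range 50 nM to 450 nM.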

Compound 3, half-maximal inhibitory concentration: 860 nM
Compound 3: middle estimate off by 5.7-fold (0.76 log units), on the low side; the whole stated range lies below it.
By their numbers in this assay, from the lowest: compound 1; then compound 3; then compound 2.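

Within the data shown here, the ester chain is not a silent position in this assay: ethoxy to 2-hydroxyethoxy gives a 9.6-fold higher number from compound 1 to compound 3 (0.98 log units; beyond the scatter) and is the only single-change step at hand. This step lies beyond the scatter, so the read-out responds to a change at the far end of the chain while the core of compound 1 stays the same. Within this one pair, hydroxy on a saturated chain carbon, two bonds along the chain from an oxygen next to a carbonyl group, goes with weaker inhibition; no measurement at hand bears on the reason for this.

Going by these compounds, whether other groups at this chain end behave alike stays open, among them an amine, a carboxylic acid or a longer chain bearing the hydroxy. Also open, on these data alone, is whether the same step holds with other substituents on the shared core.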